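This account rests on a few compounds, and the source may have more. Where it says the series, first, only, none or still open, it means among the compounds named here.

Measured so far in an ADME assay on Raji cells (Homo sapiens) for cytotoxicity, with a stated time of 72 h; a lower number here means that less compound is needed, a higher number that more compound is needed for the effect:
Compound 1 `O=C(Nc1ccc(O)c(-c2nc3ccccc3s2)c1)c1cc([N+](=O)[O-])ccc1Cl` gives > 25000 nM (a limit)
Compound 2 `O=C(Nc1ccc(Cl)c(-c2nc3ccccc3s2)c1)c1cc([N+](=O)[O-])ccc1Cl` gives > 25000 nM (a limit)
Compound 3 `COc1ccc(NC(=O)c2cc([N+](=O)[O-])ccc2Cl)cc1-c1nc2ccccc2s1` gives > 25000 nM (a limit)

Compound 2 has only a limit and no true number, > 25000 nM. The other two compounds are in the same position, since the whole set rests on (the limit of > 25000 nM in this assay, at which 3 of the 3 values shown sit). The step to compound 4 `O=C(Nc1ccc(Cl)c(C(F)(F)F)c1)c1cc([N+](=O)[O-])ccc1Cl` removes the 1,3-benzothiazol-2-yl and puts a trifluoromethyl on that aromatic carbon, ortho to a chloro group: trifluoromethyl in place of 1,3-benzothiazol-2-yl on an aromatic carbon. This exchanges a large two-ring group for a small group with no ring.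

The measured steps offer little guidance. They are a step that the two limits leave unreadable from compound 1 to compound 2, a step that the two limits leave unreadable from compound 1 to compound 3 and a step that the two limits leave unreadable from compound 2 to compound 3. None has a readable size, and all of them keep the 1,3-benzothiazol-2-yl, so none tests the present change. The data therefore point to no direction in this assay, and no step beyond the usual scatter is expected. There is also a good chance that compound 4 will return only a limit. The expected change is a number no higher from compound 2 to compound 4 (the limit leaves the size open). The estimate for compound 4 is 25000 nM, with an expected range from 8000 nM to 50000 nM.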

Compound 4, half-maximal effective concentration: > 27000 nM
Compound 4 ended at the assay's limit; the forecaster's own chance of this, stated with the estimate: 70%; at least 1.0-fold (0.03 log units) between middle value and limit.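

In this assay compound 4 gives > 27000 nM, which is a limit of the assay and not a true number. Compound 2 also has only a limit, so no step can be read between compound 2 and compound 4. The compounds shown leave open how much of each is actually needed for the effect in this assay, and whether any of these changes alters that amount.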